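The source may report more compounds than this note shows. Statements on the series, on what has been measured and on what is new or still open speak of the compounds shown alone.

Compound 1, `CCc1cc2ccccc2nc1-c1cc(-c2ccc(C)cc2)no1`: in a functional assay on MDA-MB-231 cells (Homo sapiens) for inhibition, read by MTT assay, with a stated time of 24 h (on this read-out higher numbers stand for weaker inhibition and lower numbers for stronger inhibition), compound 1 gives > 100000 nM, which is a limit of the assay and not a number.
Compound 2, `CCCc1cc2ccccc2nc1-c1cc(-c2ccc(C)cc2)no1`: in this assay compound 2 gives > 100000 nM, again a limit.
Compound 3, `CCCCc1cc2ccccc2nc1-c1cc(-c2ccc(C)cc2)no1`: in this assay compound 3 gives > 100000 nM, again a limit.

Compound 3 therefore stands only at a limit in this assay; where it sits relative to compound 1 and compound 2 cannot be read from the numbers shown. The steps a step that the two limits leave unreadable from compound 1 to compound 2, a step that the two limits leave unreadable from compound 1 to compound 3 and a step that the two limits leave unreadable from compound 2 to compound 3 all remain unreadable because the limit of > 100000 nM in this assay, at which 3 of the 3 values shown sit, caps every value in the series.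

Compound 4 is `CCCCCc1cc2ccccc2nc1-c1cc(-c2ccc(C)cc2)no1`. It differs from compound 3 by methyl in place of hydrogen on a saturated chain carbon, four bonds along the chain from an aromatic carbon. This is the same kind of lengthening of the chain on the shared core as from compound 1 to compound 2 and from compound 2 to compound 3, so those two steps bear on it, but their size is not readable. Among the compounds with values here, nothing among the measured compounds shows the chain length moving the read-out off the limit, so no step beyond the scatter is expected here; the step from compound 3 to compound 4 is estimated as a step that the limit leaves unreadable from compound 3 to compound 4. For compound 4 the expected value in this assay is 150000 nM, with a range from 60000 nM to 400000 nM, and most likely it will again be reported only as a limit.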

Compound 4, half-maximal inhibitory concentration: > 100000 nM
Compound 4 gave a limit, no number; the forecaster's own chance of this, stated with the estimate: 85%; the middle value is on the limit's open side.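

In this assay compound 4 gives > 100000 nM, again a limit and not a number. No step from compound 1, compound 2 or compound 3 to compound 4 can be read, because all the values sit at one limit: the limit of > 100000 nM in this assay, at which 4 of the 4 values shown sit.

The compounds shown leave open whether any chain on the shared core moves the read-out off this limit.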